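From compound 2 to compound 3: a cytotoxicity note

This account rests on a few compounds, and the source may have more. Where it says the series, first, only, none or still open, it means among the compounds named here.

Compound 1 `CC(C)(C)C#Cc1cc(N(C(=O)[C@H]2CC[C@H](C)CC2)[C@H]2CC[C@](O)(CO[C@H]3CCOC3)CC2)c(C(=O)O)s1` gives > 20000 nM as a limit
Compound 2 `CC(C)(C)C#Cc1cc(N(C(=O)[C@H]2CC[C@H](C)CC2)[C@H]2CC[C@H](Oc3nccs3)CC2)c(C(=O)O)s1` gives > 20000 nM as a limit

Both entries come from an ADME assay on MT4 cells (Homo sapiens) for cytotoxicity, with a stated time of 5 days (a lower number here means that less compound is tolerated, a higher number that more compound is tolerated), and neither is a number. Compound 2 stands at the limit of > 20000 nM in this assay, at which 2 of the 2 values shown sit, and cannot be ranked against compound 1. Compound 3 `CC(C)(C)C#Cc1cc(N(C(=O)[C@H]2CC[C@H](C)CC2)[C@H]2CC[C@H](O)CC2)c(C(=O)O)s1` differs from compound 2 by hydrogen in place of 1,3-thiazol-2-yl on an oxygen on a saturated carbon with hydrogen in place of 1,3-thiazol-2-yl on an oxygen on a saturated carbon, turning (1,3-thiazol-2-yl)oxy into hydroxy. Going by the values given here, no measured step shows what such a change does. The expectation therefore leans on compound 2 at > 20000 nM as a limit and nothing more. In this assay no step beyond the scatter is expected in either direction, and a report as a limit is the likeliest outcome. The expected step of a number no higher from compound 2 to compound 3 (the limit leaves the size open) is an estimate only. For compound 3 the estimated value is 20000 nM with an expected range from 12000 nM to 40000 nM for this read-out.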

Compound 3, half-maximal cytotoxic concentration: > 20000 nM
Compound 3: only a limit was reported; the forecaster's own chance of this, stated with the estimate: 80%; the middle value sits exactly at the limit.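

Compound 1, compound 2 and compound 3 are all reported as limits, so no step to compound 3 can be read: the limit of > 20000 nM in this assay, at which 3 of the 3 values shown sit.

The compounds shown leave open what the change from (1,3-thiazol-2-yl)oxy to hydroxy does in this assay, and where any of the three would reach a half-maximal cytotoxic concentration.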